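Removing the methyl from compound 3

The compounds below may be only part of what the source reports. "The series", "measured", "known", "first", "only" and "open" are said of these compounds alone.

In a functional assay on NCI-H460 cells (Homo sapiens) for cytotoxicity, read by MTT assay, with a stated time of 68 h (a lower number here means a stronger inhibitor, a higher number a weaker inhibitor), compound 1 `O=C(Nc1cccc(-c2ccccc2C(F)(F)F)c1)C(Cl)Cl` gives 7550 nM, and compound 2 `O=C(Nc1cccc(-c2ccc(-c3ccccc3)cc2)c1)C(Cl)Cl` gives 10900 nM. Compound 3 `Cc1cccc(-c2cccc(NC(=O)C(Cl)Cl)c2)c1` gives 24300 nM, the highest of the three numbers. It lies beyond the scatter of both others, with compound 2 nearest and compound 1 furthest.

Compound 4 `O=C(Nc1cccc(-c2ccccc2)c1)C(Cl)Cl` has not yet been measured. It departs from compound 3 by one small change: hydrogen in place of methyl on an aromatic carbon This places hydrogen in place of methyl on an aromatic carbon.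

Among the measured compounds shown here, no pair of measured compounds differs in one place, so the series gives no direct size for this change. The expectation therefore stays close to compound 3 at 24300 nM, with a wide range. The expected step of a 1.2-fold higher number from compound 3 to compound 4 (0.06 log units; within the scatter) is not expected to go beyond the scatter in this assay. Compound 4 is estimated at 28000 nM, with an expected range of 13000 nM to 60000 nM.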

Compound 4, half-maximal inhibitory concentration: 20200 nM
The estimate for compound 4 lay 1.4-fold (0.14 log units) above the measured number; measured number inside the range.
By their numbers in this assay, from the lowest: compounds 1, 2, 4 and 3 (each within the scatter of the next, the first and the last beyond it).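

In this assay the methyl on this aromatic carbon proves dispensable, with a 1.2-fold lower number from compound 3 to compound 4 (0.08 log units; within the scatter) as the size of its removal, and hydrogen in place of phenyl likewise stays small at a 1.9-fold higher number from compound 2 to compound 4 (0.27 log units; within the scatter) in the same read-out. Only hydrogen in place of trifluoromethyl gives a step beyond the scatter, a modest one at a 2.7-fold higher number from compound 1 to compound 4 (0.43 log units; beyond the scatter) in this series, so compound 4 now serves as the reference for all three groups. Nothing at hand bears on why the trifluoromethyl step alone stands out.

From the compounds shown here alone, whether an amine, a carboxylic acid or a methoxy group on the six-membered aromatic ring would shift the number further remains open. Also open, going by these compounds, is how the number would respond to a change in the shared core itself rather than in these ring groups.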